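Replacing 4-methylphenyl with thiophen-3-yl at the assay limit

The source may report more compounds than this note shows. Statements on the series, on what has been measured and on what is new or still open speak of the compounds shown alone.

Compound 1 `Cc1ccc(-c2nc3ccccn3c2Sc2ccccc2)cc1` gives > 100000 nM (limit)
Compound 2 `COc1cccc(OC)c1-c1nc2ccccn2c1Sc1ccccc1` gives > 100000 nM (limit)

In a functional assay on U-87MG ATCC cells for inhibition, with U-87 MG (Homo sapiens) as the target, read by MTT assay, with a stated time of 48 h (on this read-out lower numbers stand for stronger inhibition and higher numbers for weaker inhibition), compound 1 gives > 100000 nM as a limit of the assay, not a number. Compound 2 gives > 100000 nM as a limit too. Compound 1 thus stands with compound 2 (the limit of > 100000 nM in this assay, at which 2 of the 2 values shown sit). Compound 3 `c1ccc(Sc2c(-c3ccsc3)nc3ccccn23)cc1` carries thiophen-3-yl in place of 4-methylphenyl on an aromatic carbon. No step beyond the scatter is expected in this assay and no direction is favoured. The expected size is a number no higher from compound 1 to compound 3 (the limit leaves the size open) (an estimate). Compound 3 is estimated at 100000 nM (expected range 30000 nM to 200000 nM).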

Compound 3, half-maximal inhibitory concentration: 58600 nM
Estimate against measurement, compound 3: 1.7-fold (0.23 log units) above, within the range that was stated.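

In this assay, among the compounds shown here, thiophen-3-yl on this aromatic carbon gives the first reading that is a number rather than a limit, with compound 3 at 58600 nM. As far as these compounds go, replacing 4-methylphenyl with thiophen-3-yl gives an at least 1.7-fold lower number from compound 1 to compound 3 (0.23 log units; that floor lies within the scatter), and the true size of that step stays open, since its starting point is a limit and not a number. The limit still holds most of the values shown: the limit of > 100000 nM in this assay, at which 2 of the 3 values shown sit.

From the compounds shown here alone, it remains open whether an amine or a carboxylic acid on this aromatic carbon would bring the number clearly lower.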